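Allyl sulfide in place of phenethyl on a shared core

A few compounds are considered here, and "the series" means these few. Any claim that something is new, unique, unknown or untested is made for them only; others in the source may bear on it.

Measured compounds:
compound 1 `Cc1ccc(CSc2nc3nc(C)cc(Nc4cc(-c5ccccc5)[nH]n4)n3n2)cc1`, 6960 nM
compound 2 `Cc1cc(Nc2cc(-c3ccccc3)[nH]n2)n2nc(SCc3csc4ccccc34)nc2n1`, 2280 nM
compound 3 `Cc1cc(Nc2cc(-c3ccccc3)[nH]n2)n2nc(SCCc3ccccc3)nc2n1`, 5620 nM

In a functional assay on MGC-803 cells (Homo sapiens) for inhibition, read by MTT assay, with a stated time of 72 h (on this read-out lower numbers stand for stronger inhibition and higher numbers for weaker inhibition), compound 3 stands second highest of the three numbers; its nearest neighbour is compound 1, with a step within the scatter a 1.2-fold lower number from compound 1 to compound 3 (0.09 log units; within the scatter), while the step from compound 2 is larger a 2.5-fold higher number from compound 2 to compound 3 (0.39 log units; beyond the scatter). Compound 4 `C=CCSc1nc2nc(C)cc(Nc3cc(-c4ccccc4)[nH]n3)n2n1` differs from compound 3 by vinyl in place of benzyl on a saturated chain carbon bound to a sulfur. Among the compounds with values here, no measured step removes the ring altogether; the steps of a 3.1-fold lower number from compound 1 to compound 2 (0.48 log units; beyond the scatter) and a 2.5-fold higher number from compound 2 to compound 3 (0.39 log units; beyond the scatter) only show that exchanging one ring for another shifts this assay modestly. A modest rise in the number is therefore expected for compound 4, a 1.7-fold higher number from compound 3 to compound 4 (0.23 log units; within the scatter). Compound 4 is estimated at 9500 nM, within 3500 nM to 26000 nM.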

Compound 4, half-maximal inhibitory concentration: 17200 nM
Compound 4: middle estimate off by 1.8-fold (0.26 log units), on the low side, and the stated range covers the measured number.
By their numbers in this assay, from the lowest: compound 2; then compounds 3 and 1 (each within the scatter of the next); then compound 4.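

Within the data shown here, replacing benzyl with vinyl on the saturated chain carbon bound to a sulfur gives the first compound here without a ring in this group, and in this assay it raises the number beyond the scatter (a 3.1-fold higher number from compound 3 to compound 4 (0.49 log units; beyond the scatter)). Compound 4 also stands beyond the scatter of the other two ring-bearing compounds (a 2.5-fold higher number from compound 1 to compound 4 (0.39 log units; beyond the scatter); a 7.5-fold higher number from compound 2 to compound 4 (0.88 log units; beyond the scatter)), so ring exchanges shifted the number less than this change did from compound 3. Nothing measured explains this rise.

With allyl the only ringless group shown, the effects of losing the ring and of gaining the double bond cannot be separated. A saturated propyl chain, a longer chain or an amine at this place would bear on that question.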